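Changing the Sulfur-Linked Ring in a Weak Antiproliferative Series

A few compounds are considered here, and "the series" means these few. Any claim that something is new, unique, unknown or untested is made for them only; others in the source may bear on it.

compound 1 `O=C(Nc1cc(Sc2ncn[nH]2)c(O)c2ccccc12)c1ccc([N+](=O)[O-])cc1`: 53500 nM
compound 2 `O=C(Nc1cc(Sc2ncn[nH]2)c(O)c2ccccc12)c1cccc(Cl)c1`: 85600 nM
compound 3 `O=C(/C=C/c1ccccc1)Nc1cc(Sc2ncn[nH]2)c(O)c2ccccc12`: only a limit of the assay, > 100000 nM

These three share one core and differ only in the group on the carbonyl carbon. In a functional assay on PC-3 cells (Homo sapiens) for antiproliferative activity, read by MTT assay, with a stated time of 48 h (a higher number here means a weaker inhibitor, a lower number a stronger inhibitor), compound 1 and compound 2 sit within the scatter of each other, a 1.6-fold higher number from compound 1 to compound 2 (0.20 log units; within the scatter). Compound 3 reaches only the limit (the limit of > 100000 nM in this assay, at which 1 of the 3 values shown sits), so an at least 1.8-fold higher number from compound 1 to compound 3 (0.27 log units; that floor lies within the scatter) and an at least 1.1-fold higher number from compound 2 to compound 3 (0.06 log units; that floor lies within the scatter) are floors, not numbers.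

Compound 4 `O=C(Nc1cc(Sc2ncnc3nc[nH]c23)c(O)c2ccccc12)c1ccc([N+](=O)[O-])cc1` is the unmeasured compound; it differs from compound 1 by a group of 9 heavy atoms (5 carbon, 4 nitrogen; one five-membered aromatic ring with 2 hetero atoms, one six-membered aromatic ring with 2 hetero atoms) in place of a group of 5 heavy atoms (2 carbon, 3 nitrogen; one five-membered aromatic ring with 3 hetero atoms), on a sulfur. For the measured compounds named here, no measured step touches this sulfur-linked group, so none of them bears on the change. With nothing to point either way, compound 4 is expected to give 55000 nM, with a range from 20000 nM to 150000 nM. The expected step of a 1.0-fold higher number from compound 1 to compound 4 (0.01 log units; within the scatter) is therefore none beyond the scatter.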

Compound 4, half-maximal inhibitory concentration: > 100000 nM
Compound 4 was reported as a limit (the forecaster's own chance of this, stated with the estimate: 30%); at least 1.8-fold (0.25 log units) between middle value and limit.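

Compound 4 gives only a limit of the assay, not a number. In this assay, the only change shown on the sulfur, the group of 9 heavy atoms in place of 1H-1,2,4-triazol-5-yl, therefore gives a floor, an at least 1.8-fold higher number from compound 1 to compound 4 (0.27 log units; that floor lies within the scatter), so it shows no gain, and the true size of the step stays unknown. Limits now recur in this small set: the limit of > 100000 nM in this assay, at which 2 of the 4 values shown sit.

From the compounds shown here alone, whether a plain phenyl or a methyl on the sulfur would give a measurable number remains open. So does whether the same ring change would behave alike with 3-chlorophenyl on the carbonyl carbon.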